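The source may report more compounds than this note shows. Statements on the series, on what has been measured and on what is new or still open speak of the compounds shown alone.

In a functional assay on DU-145 cells (Homo sapiens) for inhibition, read by trypan blue exclusion, with a stated time of 72 h (a lower number here means a stronger inhibitor, a higher number a weaker inhibitor), compound 1 `Cc1ccc(S(=O)(=O)c2cc3cnc(Nc4ccc5[nH]ccc5c4)nc3n(C)c2=O)cc1` gives 750 nM, the lowest of the three numbers recorded. Compound 2 `COc1ccc(Nc2ncc3cc(S(=O)(=O)c4ccc(C)cc4)c(=O)n(C)c3n2)cc1` gives 100000 nM and compound 3 `Cc1ccc(S(=O)(=O)c2cc3cnc(Nc4ccc5ncccc5c4)nc3n(C)c2=O)cc1` gives 10000 nM; the steps of a 130-fold higher number from compound 1 to compound 2 (2.12 log units; beyond the scatter) and a 13-fold higher number from compound 1 to compound 3 (1.12 log units; beyond the scatter) both alter the group on a nitrogen on an aromatic ring, and a 10-fold lower number from compound 2 to compound 3 (1.00 log units; beyond the scatter) lies on the same part of the molecule. Compound 4 `Cn1c(=O)c(S(=O)(=O)c2ccc(F)cc2N)cc2cnc(Nc3ccc4[nH]ccc4c3)nc21` is not yet measured and differs from compound 1 elsewhere: 2-amino-4-fluorophenyl in place of 4-methylphenyl on a sulfonyl sulfur. For the measured compounds named here, none of the measured steps touches the sulfonyl sulfur, so they give no direct guide to this change, while the group that goes with the lowest number is kept. With nothing pointing either way, a step within the scatter is expected, no change at the digits printed from compound 1 to compound 4 (within the scatter). Compound 4 is therefore estimated at 750 nM, within a range of 250 nM to 3000 nM.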

Compound 4, half-maximal inhibitory concentration: 3000 nM
Estimate against measurement, compound 4: 4.0-fold (0.60 log units) below; low and high end bracket the measured number.
By their numbers in this assay, from the lowest: compound 1; then compound 4; then compound 3; then compound 2.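

In this assay, for the compounds shown here, the earlier compounds varied only the group on the nitrogen, and this result shows that the group on the sulfonyl sulfur also matters: 2-amino-4-fluorophenyl in place of 4-methylphenyl gives a 4.0-fold higher number from compound 1 to compound 4 (0.60 log units; beyond the scatter). That step lies beyond the scatter, yet it is smaller than a 13-fold higher number from compound 1 to compound 3 (1.12 log units; beyond the scatter), the nearer of the two steps from compound 1 on the nitrogen. No measurement shown here gives a reason for the step. As far as these compounds go, whether the amine or the fluorine carries it stays open. So does how a 4-fluorophenyl or a 2-aminophenyl group on the sulfonyl sulfur would read.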